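Benzylamino to isopropylamino: a step among limits

This account rests on a few compounds, and the source may have more. Where it says the series, first, only, none or still open, it means among the compounds named here.

Measured in an ADME assay on Akata cells (Homo sapiens) for cytotoxicity, with a stated time of 7 days; on this read-out lower numbers stand for higher toxicity in this test and higher numbers for lower toxicity in this test:
- compound 1 `Nc1nc(OCC(F)(F)F)c2ncn(/C=C3/CC3(CO)CO)c2n1`: > 20000 nM
- compound 2 `Nc1nc(NCc2ccccc2)c2ncn(/C=C3/CC3(CO)CO)c2n1`: > 24000 nM

Compound 2 stands at > 24000 nM, which is a limit and not a number. Compound 1 likewise gives a limit, > 20000 nM. Compound 3 `CC(C)Nc1nc(N)nc2c1ncn2/C=C1/CC1(CO)CO` keeps the core of compound 2 and exchanges one group: isopropyl in place of benzyl on a nitrogen on an aromatic ring. That is isopropyl in place of benzyl on a nitrogen on an aromatic ring. Among the measured compounds shown here, the one measured step that bears on this is a step that the two limits leave unreadable from compound 1 to compound 2, where benzylamino took the place of 2,2,2-trifluoroethoxy on an aromatic carbon. On the strength of that step, a step that the two limits leave unreadable from compound 1 to compound 2, no step beyond the scatter is expected in this assay, in either direction. The estimated change is a step that the limit leaves unreadable from compound 2 to compound 3. Compound 3 is expected at 25000 nM, with an estimated range from 10000 nM to 60000 nM.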

Compound 3, half-maximal cytotoxic concentration: > 24000 nM
Compound 3: a limit, no number; the forecaster's own chance of this, stated with the estimate: 80%; the middle value lies beyond the limit too.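

In this assay compound 3 gives > 24000 nM, which is a limit and not a number. Compound 1 and compound 2 also give only limits, so no step between any of these compounds can be read. From the compounds shown here alone, how far each true value lies beyond its limit, and whether the exchanged groups shift it at all, stays open.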